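A few compounds are considered here, and "the series" means these few. Any claim that something is new, unique, unknown or untested is made for them only; others in the source may bear on it.

Measured compounds:
- compound 1, `CS(=O)(=O)c1ccc(Cl)cc1NCC1=NCCN1`, 61.7 nM
- compound 2, `COc1ccc(SC)c(NCC2=NCCN2)c1`, 3.63 nM
- compound 3, `CS(=O)(=O)c1c(F)cccc1NCC1=NCCN1`, < 100000 nM, which is a limit of the assay rather than a number

These three share a core and were tested in a functional assay for agonist activity at Alpha-1B adrenergic receptor (Homo sapiens); a higher number here means that more compound is needed for the effect, a lower number that less compound is needed. Compound 1 gives 61.7 nM, the highest of the two numbers reported. Compound 2, with its 3.63 nM, sits at a lower number, and that gap is beyond the usual scatter of repeated measurements. For compound 3 the assay returns only a limit, (the limit of < 100000 nM in this assay, at which 1 of the 3 values shown sits), so no number can be placed beside the other two.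

The next compound, compound 4, is `CS(=O)(=O)c1ccc(C(F)(F)F)cc1NCC1=NCCN1`. It differs from compound 1 in one place: trifluoromethyl in place of chloro on an aromatic carbon. Going by the values given here, no measured pair in this set shows such an exchange, so the expected size of the step rests on compound 1 alone. Because compound 1 gives 61.7 nM, and the change keeps the rest of the molecule intact, a modest step toward a higher number is expected, of the size a 1.8-fold higher number from compound 1 to compound 4 (0.25 log units; within the scatter), although a step within the scatter would be no surprise. Compound 4 is therefore estimated at 110 nM in this assay, with a likely range from 25 nM to 450 nM.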

Compound 4, half-maximal effective concentration: < 100000 nM
Compound 4 gave a limit, no number; the forecaster's own chance of this, stated with the estimate: 10%; the middle value lies beyond the limit too.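

In this assay compound 4 returns < 100000 nM which is a limit of the assay and not a number. The step from compound 1 to compound 4 therefore cannot be read. The compounds shown leave open how far trifluoromethyl in place of chloro moves the number, and whether compound 3 and compound 4 differ at all.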